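The compounds below may be only part of what the source reports. "The series", "measured", "known", "first", "only" and "open" are said of these compounds alone.

Compound 1: `COc1cc(Cl)cc(-c2nn(-c3cccc(NC(=O)Nc4ccc(Cl)c(Cl)c4)c3)cc2-c2ccncc2)c1`, giving 1.93% in a functional assay on OVCAR-8 cells (Homo sapiens) for inhibition, read by sulforhodamine B assay, with a stated time of 48 h, tested at 10 uM; a lower number here means a stronger effect, a higher number a weaker effect of the compound at the concentration tested.
Compound 2: `COc1cc(Cl)cc(-c2nn(-c3cccc(NC(=O)Nc4cccc(C(F)(F)F)c4)c3)cc2-c2ccncc2)c1`, giving -12.3% in this assay.
Compound 3: `COc1cc(Cl)cc(-c2nn(-c3cccc(NC(=O)c4cccc(C(F)(F)F)c4)c3)cc2-c2ccncc2)c1`, giving 42% in this assay.

Compound 3 stands at the highest of the three numbers in this assay, which here means the weakest effect of the three at the tested concentration. The step of a number 40.1 percentage points higher from compound 1 to compound 3 (beyond the scatter) was large, and a number 54.3 percentage points higher from compound 2 to compound 3 (beyond the scatter) was larger still, while a number 14.2 percentage points lower from compound 1 to compound 2 (beyond the scatter) was only modest.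

Compound 4 is `COc1cc(Cl)cc(-c2nn(-c3cccc(NC(=O)c4cc(C(F)(F)F)cc(C(F)(F)F)c4)c3)cc2-c2ccncc2)c1`. It differs from compound 3 by trifluoromethyl in place of hydrogen on an aromatic carbon. Within the data shown here, none of the measured steps touches this part of the molecule: a number 40.1 percentage points higher from compound 1 to compound 3 (beyond the scatter) and a number 54.3 percentage points higher from compound 2 to compound 3 (beyond the scatter) change what sits on the carbonyl carbon, and a number 14.2 percentage points lower from compound 1 to compound 2 (beyond the scatter) swaps groups on an amide-type nitrogen, so they give no direct guide to adding a second trifluoromethyl group. With nothing to anchor a shift in either direction, the expectation for this assay is a step of about a number 4 percentage points lower from compound 3 to compound 4 (within the scatter), that is, no change beyond the scatter, and the range is kept wide. Compound 4 is therefore estimated at 38%, with a range from 5% to 70%.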

Compound 4, a percentage reported as activity, at one concentration (the size of the read-out at that concentration, not a potency): 55.4%
Compound 4: the middle estimate sits 17.4 percentage points below what was measured, within the range that was stated.
By their numbers in this assay, from the lowest: compound 2; then compound 1; then compound 3; then compound 4.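

The aromatic ring that carries the trifluoromethyl group is not a neutral spot in this series: with the rest of compound 3 unchanged, adding one more trifluoromethyl group, meta to a large group and meta to the first trifluoromethyl group, gives in this assay a number 13.4 percentage points higher from compound 3 to compound 4 (beyond the scatter). Since a higher number here means a weaker effect at the concentration tested, this addition costs some effect, though the step is smaller than those seen when the group on the carbonyl carbon was exchanged. Among these compounds, the earlier compounds changed the link to this ring or the substituents on a ring joined through an amide-type nitrogen, so this is the first view of what a substitution on this ring does while that link stays the same, and nothing measured here accounts for the shift.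

Going by these compounds, this single pair cannot separate the effect of this position from the effect of this particular group, so it remains open whether a smaller or very different substituent there, such as a methyl group, an amine or a carboxylic acid, would also weaken the effect. On these data alone, it is equally open whether a second trifluoromethyl group would act the same way on the urea-linked compound 2.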